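From compound 3 to its fluoro analogue

The source may report more compounds than this note shows. Statements on the series, on what has been measured and on what is new or still open speak of the compounds shown alone.

- compound 1 `COc1cc2c(Oc3ccc(NC(=O)Nc4ccccc4Cl)cc3)ccnc2cc1OCCCCCCC(=O)NO`: 1910 nM
- compound 2 `COc1ccccc1NC(=O)Nc1ccc(Oc2ccnc3cc(OCCCCCCC(=O)NO)c(OC)cc23)cc1`: 16200 nM
- compound 3 `COc1cc2c(Oc3ccc(NC(=O)N/N=C/c4ccccc4)cc3)ccnc2cc1OCCCCCCC(=O)NO`: 3700 nM

In a functional assay on A549 cells (Homo sapiens) for antiproliferative activity, read by MTT assay (on this read-out lower numbers stand for stronger inhibition and higher numbers for weaker inhibition), compound 3 gives 3700 nM. That matches compound 1 within the scatter, a 1.9-fold higher number from compound 1 to compound 3 (0.29 log units; within the scatter), and is clearly stronger than compound 2, a 4.4-fold lower number from compound 2 to compound 3 (0.64 log units; beyond the scatter). Compound 4 `COc1cc2c(Oc3ccc(NC(=O)N/N=C/c4ccc(F)cc4)cc3)ccnc2cc1OCCCCCCC(=O)NO` differs from compound 3 by one change: fluoro in place of hydrogen on an aromatic carbon. Among the compounds with values here, no measured step makes this swap. The closest is methoxy in place of chloro on an aromatic carbon, an 8.5-fold higher number from compound 1 to compound 2 (0.93 log units; beyond the scatter), a modest step between two larger groups elsewhere in the molecule, so it is only a loose guide. Little change is therefore expected, with no firm direction: a 1.1-fold lower number from compound 3 to compound 4 (0.05 log units; within the scatter). The estimated value for compound 4 is 3300 nM, with an expected range of 1300 nM to 8500 nM.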

Compound 4, half-maximal inhibitory concentration: 4920 nM
Beside the measured number, compound 4's estimate is 1.5-fold (0.17 log units) below it; low and high end bracket the measured number.
By their numbers in this assay, from the lowest: compounds 1, 3 and 4 (each within the scatter of the next, the first and the last beyond it); then compound 2.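

In this assay, the swap of phenyl for 4-fluorophenyl leaves no mark that can be told from noise: a 1.3-fold higher number from compound 3 to compound 4 (0.12 log units; within the scatter). The fluoro analogue remains clear of the methoxy urea, a 3.3-fold lower number from compound 2 to compound 4 (0.52 log units; beyond the scatter), but unlike its parent it also separates from the chloro urea, a 2.6-fold higher number from compound 1 to compound 4 (0.41 log units; beyond the scatter). Nothing available here explains these steps. From the compounds shown here alone, whether a larger group at this same place, such as trifluoromethyl, or an amine would shift the number stays open, as does whether fluoro would matter on a different ring carbon.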